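The source may hold more compounds than are shown below. What is called first, only, known or untested is meant among the compounds shown, and "the series" means these compounds.

Working notes on a small series of four related compounds tested in a functional assay on MCF7 cells (Homo sapiens) for cytotoxicity, read by MTT assay; a lower number here means a stronger inhibitor, a higher number a weaker inhibitor. Compound 1 `CC(=O)O[C@@H]1OC(=O)[C@](O)(C(C)=O)[C@@H]1C` is the parent of the set. In this assay compound 1 gives no number but only a limit of the assay, > 50000 nM. Compound 2 `CC(=O)O[C@@H]1OC(=O)[C@](OC(C)=O)(C(C)=O)[C@@H]1C` differs from compound 1 by acetyl in place of hydrogen on an oxygen on a saturated carbon. In this assay compound 2 likewise returns a limit rather than a number, > 50000 nM. Compound 3 `CC(=O)O[C@@H]1OC(=O)[C@@](O)(C(C)=O)[C@@H]1C` shares every atom and bond with compound 1; the difference between the two cores is the two compounds have the same atoms and bonds and differ only in configuration as drawn: 1 of 3 stereo elements differ; a stereocentre at a saturated ring carbon is drawn R in compound 1 and S in compound 3. In this assay compound 3 also reaches only a limit, > 50000 nM. The step that the two limits leave unreadable from compound 1 to compound 2 cannot be sized because of the limit of > 50000 nM in this assay, at which 3 of the 3 values shown sit. The same holds for a step that the two limits leave unreadable from compound 1 to compound 3, which cannot be sized because of the limit of > 50000 nM in this assay, at which 3 of the 3 values shown sit; that the pair is a stereo pair, (the fact that compounds 1 and 3 differ only in the configuration as drawn), gives nothing readable on top of that.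

Compound 4 `CC(=O)O[C@@H]1OC(=O)[C@@](OC(C)=O)(C(C)=O)[C@@H]1C` has not yet been measured. Among the measured compounds shown here, it differs from compound 3 by acetyl in place of hydrogen on an oxygen on a saturated carbon, the same change, at the same place, as the one that turns compound 1 into compound 2. With all three measured compounds sitting at the limit, (the limit of > 50000 nM in this assay, at which 3 of the 3 values shown sit), the step that the limit leaves unreadable from compound 3 to compound 4 is expected to be flat, so that compound 4 is expected to return a limit as well. The estimate for compound 4 is 80000 nM, with an expected range from 30000 nM to 300000 nM.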

Compound 4, half-maximal inhibitory concentration: > 50000 nM
Compound 4: no number, only a limit; the forecaster's own chance of this, stated with the estimate: 85%; the middle value lies beyond the limit too.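

In this assay compound 4 also returns only a limit of the assay, > 50000 nM. Neither the step from compound 3 to compound 4 nor the step from compound 2 to compound 4 can be read, because every value sits at that limit: the limit of > 50000 nM in this assay, at which 4 of the 4 values shown sit.

The compounds shown leave open whether the hydroxy to acetoxy change or the configuration at the saturated ring carbon alters the read-out in this assay at all.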